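The compounds below may be only part of what the source reports. "The series", "measured", "known", "first", "only" and "open" are said of these compounds alone.

Measured compounds in a functional assay on HEK293 cells for agonist activity at growth hormone secretagogue receptor type 1 (Homo sapiens), read by HTRF and inositol phosphate accumulation, with a stated time of 90 min, in the presence of a further agent that is not named here; a lower number here means a smaller maximal response, a higher number a larger maximal response:
Compound 1 `Cc1ccc2[nH]c(C(=O)N[C@H]3CN(S(=O)(=O)c4cn(C)nc4C)C[C@@H]3C(=O)NCCN(C)C)cc2c1` gives 95%.
Compound 2 `Cc1ccc2[nH]c(C(=O)N[C@H]3CCN(S(=O)(=O)c4cccnc4)C[C@@H]3C(=O)NCCN(C)C)cc2c1` gives 93%.

The two values sit within the usual scatter of each other, so compound 2 stands on the same footing as compound 1; both reach nearly the full response of the reference. Compound 3 `Cc1ccc2[nH]c(C(=O)N[C@H]3CCN(S(=O)(=O)N(C)C)C[C@@H]3C(=O)NCCN(C)C)cc2c1` differs from compound 2 in one place: dimethylamino in place of pyridin-3-yl on a sulfonyl sulfur. Among the measured compounds shown here, no measured pair shows what this exchange does to the maximal response, so any expectation rests on the two values alone. In this assay the step from compound 2 to compound 3 is expected to be small, at most a modest lowering, and possibly none beyond the scatter, the expected step being a number 5 percentage points lower from compound 2 to compound 3 (within the scatter). Compound 3 is estimated to give 88%, within a range from 72% to 100%.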

Compound 3, largest response reached (Emax), in percent of the reference or control that the assay uses in the growth hormone secretagogue receptor type 1 assay: 100%
For compound 3 the middle estimate is 12 percentage points below the measured one; the measured number falls inside the stated range.
By their numbers in the growth hormone secretagogue receptor type 1 assay, from the lowest: compounds 2, 1 and 3 (each within the scatter of the next).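

In the growth hormone secretagogue receptor type 1 assay the sulfonyl sulfur takes dimethylamino in place of pyridin-3-yl, with a number 7 percentage points higher from compound 2 to compound 3 (within the scatter) as the step, so a group with no ring serves there as well as the aromatic ring, at least in this pair. In a physicochemical assay for lipophilicity, measured as octanol-water partition, at pH 7.4 (on this read-out higher numbers stand for higher lipophilicity and lower numbers for lower lipophilicity), compound 2 gives 1.3 and compound 3 gives 1.2 and the two stand level within the scatter.

As far as these compounds go, whether a morpholine or a longer alkyl chain on the same sulfonyl sulfur would keep the maximal response stays open. Nothing available accounts for the result.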